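This account rests on a few compounds, and the source may have more. Where it says the series, first, only, none or still open, it means among the compounds named here.

In a functional assay on HL-60 cells (Homo sapiens) for cytotoxicity, read by MTT assay, with a stated time of 72 h (a higher number here means a weaker inhibitor, a lower number a stronger inhibitor), compound 1 `O=C(Nc1nnc(-c2cccc(O)c2O)s1)c1ccccc1` gives 20700 nM and compound 2 `Cc1ccc(C(=O)Nc2nnc(-c3cccc(O)c3O)s2)cc1` gives 10600 nM, so compound 2 stands within the scatter of compound 1. For the measured compounds named here, the only measured step, a 2.0-fold lower number from compound 1 to compound 2 (0.29 log units; within the scatter), is methyl in place of hydrogen on an aromatic carbon. Compound 3 `O=C(Nc1nnc(-c2cccc(O)c2O)s1)C1CCCCC1` carries a different change: cyclohexyl in place of 4-methylphenyl on a carbonyl carbon. Going by the values given here, no measured step tests this change directly, so no shift beyond the scatter is expected in this assay. The expected step is a 1.4-fold higher number from compound 2 to compound 3 (0.15 log units; within the scatter). The estimate for compound 3 is 15000 nM, with an expected range of 5000 nM to 45000 nM.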

Compound 3, half-maximal inhibitory concentration: 7900 nM
Beside the measured number, compound 3's estimate is 1.9-fold (0.28 log units) above it; low and high end bracket the measured number.
By their numbers in this assay, from the lowest: compounds 3, 2 and 1 (each within the scatter of the next, the first and the last beyond it).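

In this assay, for the compounds shown here, a non-aromatic ring on the carbonyl carbon is tolerated: cyclohexyl in place of 4-methylphenyl gives a 1.3-fold lower number from compound 2 to compound 3 (0.13 log units; within the scatter) and cyclohexyl in place of phenyl gives a 2.6-fold lower number from compound 1 to compound 3 (0.42 log units; beyond the scatter) as the first step beyond the scatter, though a modest one. With only these rings compared, the series shows no loss on leaving the aromatic ring. No measured evidence accounts for either step. Still open, going by these compounds, is how an amine, a carboxylic acid or a longer chain on the carbonyl carbon would read here.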